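The source may hold more compounds than are shown below. What is called first, only, known or untested is meant among the compounds shown, and "the series" means these compounds.

Measured so far:
- compound 1 `CCOC(=O)c1sc(-c2ccccn2)nc1N1CCC(NCc2ccc(OC)cc2)CC1`: 4.62% in an ADME assay on RAW264.7 cells (Mus musculus) for cytotoxicity, read by MTT assay, with a stated time of 72 h, tested at 50 uM; a lower number here means less inhibition, a higher number more inhibition at the concentration tested (going by the name of the read-out)
- compound 2 `CCOC(=O)c1sc(-c2ccccn2)nc1N1CCC(NCc2ccc(C(F)(F)F)cc2)CC1`: 14.6%
- compound 3 `CCOC(=O)c1sc(-c2ccccn2)nc1N1CCC(NCc2ccc(Cl)c(Cl)c2)CC1`: 30.1%

Compound 3 stands highest of the three numbers. The step of a number 25.5 percentage points higher from compound 1 to compound 3 (beyond the scatter) and the step of a number 15.5 percentage points higher from compound 2 to compound 3 (beyond the scatter) are both beyond the scatter, while the step of a number 10 percentage points higher from compound 1 to compound 2 (within the scatter) is within it, so compound 3 is set apart from the other two, and compound 1 and compound 2 cannot be ordered against each other.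

Compound 4 `CCOC(=O)c1sc(-c2ccncc2)nc1N1CCC(NCc2ccc(Cl)c(Cl)c2)CC1` is the next compound. It differs from compound 3 in one place: pyridin-4-yl in place of pyridin-2-yl on an aromatic carbon. Every measured step concerns the group on the saturated chain carbon bound to the amine nitrogen, and none of them touches the position of the pyridinyl group on the core. No measured step therefore bears directly on this change, and the account can only note that a rearrangement of the same atoms, with no change in donors or acceptors, gives little reason to expect a step beyond the scatter in this assay in either direction.

Compound 4 is thus expected to give about 28%, estimated between 10% and 48%. The expected step is a number 2.1 percentage points lower from compound 3 to compound 4 (within the scatter), estimated to lie within the scatter.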

Compound 4, a percentage reported as inhibition, at one concentration (the size of the read-out at that concentration, not a potency): 32.2%
Estimate against measurement, compound 4: 4.2 percentage points below; the measured number falls inside the stated range.
By their numbers in this assay, from the lowest: compounds 1 and 2 (each within the scatter of the next); then compounds 3 and 4 (each within the scatter of the next).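

With the 3,4-dichlorophenyl group held fixed, pyridin-4-yl in place of pyridin-2-yl, on the aromatic carbon next to the ring nitrogen and next to the ring sulfur, gives in this assay a step of a number 2.1 percentage points higher from compound 3 to compound 4 (within the scatter). Within the data shown here, this is the first look at this position, as the earlier steps all concerned the aromatic group on the saturated chain carbon bound to the amine nitrogen, and it shows that these two attachments of the pyridine, with the same atoms joined differently, cannot be told apart in this read-out. No measurement at hand accounts for this result or links it to any property of either group.

Going by these compounds, it remains open whether pyridin-3-yl, a plain phenyl ring or a small alkyl chain on the same carbon would also stay within the scatter of compound 3, and whether the same exchange of pyridinyl groups would read alike with 4-methoxyphenyl or 4-(trifluoromethyl)phenyl on the other side of the molecule. The ethoxycarbonyl group is also untested by these compounds, so a carboxylic acid or a primary amide in its place remains an open question.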